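Two ring cores, one swap of a piperazine group

The compounds below may be only part of what the source reports. "The series", "measured", "known", "first", "only" and "open" are said of these compounds alone.

Of the compounds shown here, three have been measured in an ADME assay on microsomes from liver (Rattus norvegicus), read by LC-MS, with a stated time of 60 min, tested at 1 uM; on this read-out lower numbers stand for lower hepatic extraction and higher numbers for higher hepatic extraction. Compound 1 `O=C1CN(c2nccn3c(-c4ccc5c(c4)CC(=O)N5)c(-c4ccc(F)cc4)nc23)CCN1` carries a 3-oxopiperazin-1-yl group on its core, and in this assay compound 1 gives 0.7. Compound 2 `CC(=O)N1CCN(c2nccn3c(-c4ccc5c(c4)CC(=O)N5)c(-c4ccc(F)cc4)nc23)CC1` differs from it by the change (4-acetylpiperazin-1-yl in place of 3-oxopiperazin-1-yl on an aromatic carbon), and in this assay compound 2 gives 0.5, which is a number 0.20 lower from compound 1 to compound 2 (beyond the scatter). Compound 3 `O=C1CN(c2nccc3c(-c4ccc5c(c4)CC(=O)N5)c(-c4ccc(F)cc4)nn23)CCN1` is built from the same atoms as compound 1, joined differently; the difference between the two cores is not broken down here. In this assay compound 3 gives 0.6, a number within the usual scatter of those for compound 1 and compound 2.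

Compound 4 `CC(=O)N1CCN(c2nccc3c(-c4ccc5c(c4)CC(=O)N5)c(-c4ccc(F)cc4)nn23)CC1` has not yet been measured. It differs from compound 3 by 4-acetylpiperazin-1-yl in place of 3-oxopiperazin-1-yl on an aromatic carbon. Among the compounds with values here, this is the same kind of change as the one from compound 1 to compound 2, but not the same: in compound 3 the place is between two ring nitrogen atoms, whereas in compound 1 it is next to the ring nitrogen and two atoms from the ring nitrogen. Since the first swap lowered the read-out by a number 0.20 lower from compound 1 to compound 2 (beyond the scatter), a step of about the same size is expected here, written as a number 0.20 lower from compound 3 to compound 4 (beyond the scatter). Compound 4 is therefore expected to give 0.4 in this assay, within a band from 0.25 to 0.55. This rests on a single measured step, so the expectation is loosely held.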

Compound 4, hepatic extraction ratio: 0.5
For compound 4 the middle estimate is 0.10 below the measured one; the range from low to high includes it.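

In this assay, putting 4-acetylpiperazin-1-yl in place of 3-oxopiperazin-1-yl on the core of compound 3 gives a number 0.10 lower from compound 3 to compound 4 (within the scatter), so on this core the swap alone cannot be told apart from the ordinary spread of repeat measurements. Compared with the earlier step on the core of compound 1, the swap carries over as far as these numbers can tell, and the two cores cannot be separated: the same change on two cores in this assay, a number 0.20 lower (beyond the scatter) from compound 1 to compound 2 and a number 0.10 lower (within the scatter) from compound 3 to compound 4, 0.10 apart, within the scatter of two such steps This shows only that the two steps are compatible with one shared effect; it does not prove that the effect is the same on both cores, nor that the swap truly lowers the read-out on the core of compound 3, since one of the two steps stays within the scatter and each rests on a single pair of compounds.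

The compounds shown also leave open how other groups at this place would behave, such as a morpholine ring, a piperazine with a free ring nitrogen, or a longer acyl chain instead of the acetyl. They also leave open whether the same swap would behave alike on any core beyond these two.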